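The source may report more compounds than this note shows. Statements on the series, on what has been measured and on what is new or still open speak of the compounds shown alone.

Two compounds measured in a functional assay on the whole organism (artery) for inhibition, with Rattus norvegicus as the target, at a dose of 3 mg/kg by the intraduodenal route (on this read-out higher numbers stand for more inhibition at the one dose given (going by the name of the read-out) and lower numbers for less inhibition), share one core and differ only in the group carried on a saturated chain carbon bound to an aromatic carbon. Compound 1 `CCCCc1ccc(CN(C(C)C)S(C)(=O)=O)c(=O)n1Cc1ccc(-c2ccccc2-c2nn[nH]n2)cc1` gives 82.7% in this assay. Compound 2 `CCCCc1ccc(CN(C)S(=O)(=O)c2ccccc2)c(=O)n1Cc1ccc(-c2ccccc2-c2nn[nH]n2)cc1` gives 68.7%. Among the measured compounds shown here, the one step seen so far, a number 14 percentage points lower from compound 1 to compound 2 (beyond the scatter), leaves compound 2 as the lower of the two numbers, with compound 1 the nearest neighbour above it.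

Compound 3 `CCCCc1ccc(CNC(=O)NC2CCCCC2)c(=O)n1Cc1ccc(-c2ccccc2-c2nn[nH]n2)cc1` is not yet measured. Its structure differs from compound 2 in one place: (cyclohexylcarbamoyl)amino in place of methyl(phenylsulfonyl)amino on a saturated chain carbon bound to an aromatic carbon. For the measured compounds named here, this swap is larger than the measured one, since it replaces a sulfonyl-bearing group by a urea-type group, yet the only guide available is the step from compound 1 to compound 2, where a change of the same group at the same place moved the read-out down by a modest amount. A change of similar or somewhat greater size, most likely downward, is therefore expected, with wide uncertainty.

Compound 3 is estimated at 55%, within 30% to 80%, which means an expected step of a number 13.7 percentage points lower from compound 2 to compound 3 (beyond the scatter).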

Compound 3, a percentage reported as inhibition, in the whole organism at one dose (the size of the read-out at that dose, not a potency): 0%
Compound 3: the middle estimate sits 55 percentage points above what was measured; measured number outside the range, below it.
By their numbers in this assay, from the lowest: compound 3; then compound 2; then compound 1.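

In this assay, the group on a saturated chain carbon bound to an aromatic carbon can decide nearly the whole read-out: with (cyclohexylcarbamoyl)amino in place, compound 3 gives 0%, which is a number 68.7 percentage points lower from compound 2 to compound 3 (beyond the scatter) and a number 82.7 percentage points lower from compound 1 to compound 3 (beyond the scatter). The earlier change between the two sulfonyl-bearing groups gave only a number 14 percentage points lower from compound 1 to compound 2 (beyond the scatter), so this position had looked fairly forgiving, and the new result shows that this holds at most among those two groups. This swap changes several things at once, removing the sulfonyl, putting a non-aromatic ring where compound 2 has an aromatic one, and bringing in hydrogen-bond donors, and no supporting data here show which of these matters.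

The compounds shown leave open whether the loss follows the urea-type link or the cyclohexyl ring, a question that (phenylcarbamoyl)amino, which keeps the link but carries an aromatic ring, could help to separate. They also leave open how simpler groups at this place, such as an acetylamino group or a plain amine, would read out at this single dose.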